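Replacing 2-hydroxyphenyl with 3-methylphenyl on a shared core

A few compounds are considered here, and "the series" means these few. Any claim that something is new, unique, unknown or untested is made for them only; others in the source may bear on it.

compound 1 `Fc1cccc(-c2nc(Nc3ccccc3)c3cc(F)ccc3n2)c1` gives 45500 nM
compound 2 `Oc1ccccc1Nc1nc(-c2cccc(F)c2)nc2ccc(F)cc12` gives 46300 nM

Both numbers come from a functional assay on U-937 cells (Homo sapiens) for cytotoxicity, read by MTT assay, with a stated time of 48 h (on this read-out lower numbers stand for stronger inhibition and higher numbers for weaker inhibition), and lie within the scatter of each other, and compound 2 stands level with compound 1 on them. Compound 3 `Cc1cccc(Nc2nc(-c3cccc(F)c3)nc3ccc(F)cc23)c1` has not yet been measured. The change from compound 2 is 3-methylphenyl in place of 2-hydroxyphenyl on a nitrogen on an aromatic ring and reads as 3-methylphenyl in place of 2-hydroxyphenyl on a nitrogen on an aromatic ring. Among the compounds with values here, the one measured step bearing on it is a 1.0-fold higher number from compound 1 to compound 2 (0.01 log units; within the scatter) for hydroxy in place of hydrogen on an aromatic carbon. Within the data shown here, no measured compound carries the 3-methylphenyl group. Among the measured compounds shown here, with compound 1 at 45500 nM and compound 2 at 46300 nM as the only guide, no step beyond the scatter is expected in this assay here. The estimated step is a 1.2-fold lower number from compound 2 to compound 3 (0.06 log units; within the scatter) and nothing larger is expected. Compound 3 is expected at 40000 nM within an estimated range from 15000 nM to 100000 nM in this read-out.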

Compound 3, half-maximal inhibitory concentration: > 50000 nM
Compound 3: no number, only a limit; the forecaster's own chance of this, stated with the estimate: 10%; middle value at least 1.2-fold (0.09 log units) from the limit.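

In this assay compound 3 returns a limit and not a number: the limit of > 50000 nM in this assay, at which 1 of the 3 values shown sits. Read against the earlier compounds, this gives an at least 1.0-fold higher number from compound 2 to compound 3 (0.03 log units; that floor lies within the scatter) for 3-methylphenyl in place of 2-hydroxyphenyl on a nitrogen on an aromatic ring, and an at least 1.0-fold higher number from compound 1 to compound 3 (0.04 log units; that floor lies within the scatter) for methyl in place of hydrogen on an aromatic carbon. Within the data shown here, the earlier pair covered only hydroxy against hydrogen, and this result adds that a methyl group on this ring, without the hydroxy, also brings no step that can be read as beyond the scatter, and that neither floor fixes the true size of its step.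

The compounds shown leave open how far compound 3 lies past its limit. They also leave open whether an amine or a carboxylic acid on this ring, or a longer chain in place of methyl, would move the number in this position.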